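From 3-chloro-4-nitrophenyl to 4-(trifluoromethyl)phenyl on a carbonyl carbon

The source may report more compounds than this note shows. Statements on the series, on what has been measured and on what is new or still open speak of the compounds shown alone.

Compound 1 `O=C(/C(=C\c1ccc([N+](=O)[O-])c(O)c1)SCc1ccc(Br)cc1)c1ccc([N+](=O)[O-])cc1` at 1000 nM
Compound 2 `O=C(/C(=C\c1ccc([N+](=O)[O-])c(O)c1)SCc1ccc(Br)cc1)c1ccc([N+](=O)[O-])c(Cl)c1` at 1000 nM

In a functional assay on DU-145 cells (Homo sapiens) for inhibition, read by trypan blue exclusion, with a stated time of 96 h (on this read-out lower numbers stand for stronger inhibition of growth and higher numbers for weaker inhibition of growth), compound 2 gives 1000 nM and stands level with compound 1 at the digits shown. Compound 3 `O=C(/C(=C\c1ccc([N+](=O)[O-])c(O)c1)SCc1ccc(Br)cc1)c1ccc(C(F)(F)F)cc1` follows by 4-(trifluoromethyl)phenyl in place of 3-chloro-4-nitrophenyl on a carbonyl carbon with 4-(trifluoromethyl)phenyl in place of 3-chloro-4-nitrophenyl on a carbonyl carbon. Going by the values given here, one measured step bears on this, no change at the digits printed from compound 1 to compound 2 (within the scatter) for chloro in place of hydrogen on an aromatic carbon. Among the compounds with values here, no measured step removes the nitro from this group, so the expectation is weak. The expected step is no change at the digits printed from compound 2 to compound 3 (within the scatter) with no firm direction. The estimate for compound 3 is 1000 nM within an expected range from 350 nM to 3000 nM in this assay overall.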

Compound 3, concentration for 50% growth inhibition: 1000 nM
Estimate against measurement, compound 3: no gap at the digits printed; low and high end bracket the measured number.
By their numbers in this assay, from the lowest: compounds 1, 2 and 3 (each within the scatter of the next).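

In this assay the nitro group on this ring proves replaceable: trifluoromethyl in place of nitro on an aromatic carbon gives no change at the digits printed from compound 1 to compound 3 (within the scatter) and the full exchange of 3-chloro-4-nitrophenyl for 4-(trifluoromethyl)phenyl on the carbonyl carbon gives no change at the digits printed from compound 2 to compound 3 (within the scatter) as well. The entering group has 0 hydrogen-bond acceptors against 2 in the group that leaves, and the read-out stays level. Nothing at hand accounts for this. From the compounds shown here alone, whether an amine or a carboxylic acid on this ring would hold the same level stays open, as does the case of a plain phenyl on the carbonyl carbon.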